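The source may hold more compounds than are shown below. What is called first, only, known or untested is meant among the compounds shown, and "the series" means these compounds.

Compound 1 `COc1ccccc1-c1ccccc1O` and compound 2 `Nc1ccccc1-c1ccccc1O` share one core, and compound 3 `COc1cccc(-c2cccc(O)c2)c1` has the same atoms joined differently; the difference between the two cores is not broken down here. In an ADME assay on HEK293 cells (Homo sapiens) for cytotoxicity, read by MTT assay, with a stated time of 3 days (on this read-out higher numbers stand for weaker inhibition and lower numbers for stronger inhibition), compound 1 gives 54 ug/mL, and compound 2 gives 54.1 ug/mL. The change between them is amino in place of methoxy on an aromatic carbon, and it makes a 1.0-fold higher number from compound 1 to compound 2 (0.00 log units; within the scatter). In this assay compound 3 gives 34 ug/mL; against compound 1 and compound 2 this lies within the scatter, so no order among the three can be read from these numbers.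

Compound 4 `Nc1cccc(-c2cccc(O)c2)c1` is yet to be tested in this assay. It stands to compound 3 as compound 2 stands to compound 1: the change is amino in place of methoxy on an aromatic carbon. The two changes are the same kind of change, yet the surroundings differ: in compound 2 the amino stands ortho to a group of 7 heavy atoms, in compound 4 it stands meta to a group of 7 heavy atoms.

The expectation for compound 4 rests on the step seen between compound 1 and compound 2, because a 1.0-fold higher number from compound 1 to compound 2 (0.00 log units; within the scatter) was flat; the estimated step from compound 3 to compound 4 is a 1.1-fold higher number from compound 3 to compound 4 (0.02 log units; within the scatter). Compound 4 is therefore expected to give about 36 ug/mL in this assay, with the estimate lying between 20 ug/mL and 65 ug/mL, and the measured number will show whether this holds.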

Compound 4, half-maximal inhibitory concentration: 50.1 ug/mL
Estimate against measurement, compound 4: 1.4-fold (0.14 log units) below, within the range that was stated.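

In this assay, among the compounds shown here, amino in place of methoxy on the core of compound 3 gives a 1.5-fold higher number from compound 3 to compound 4 (0.17 log units; within the scatter), so the change leaves no step that can be told from repeated measurement on this core, as was already the case on the core of compound 1 with a 1.0-fold higher number from compound 1 to compound 2 (0.00 log units; within the scatter). Set side by side, the two steps do not differ, and the core carrying the change makes no difference that these numbers can show: the same change on two cores in this assay, a 1.0-fold higher number (0.00 log units; within the scatter) from compound 1 to compound 2 and a 1.5-fold higher number (0.17 log units; within the scatter) from compound 3 to compound 4, 1.5-fold (0.17 log units) apart, within the scatter of two such steps What this shows is limited but clear: on both cores the swap of methoxy for amino stays within the scatter, so in this small set the flat result carries from one core to the other; it does not show that the two steps are truly equal, that the swap has no effect at all, or that the same would hold on any core beyond these two.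

The compounds shown hold only methoxy or amino at this place, so what a nitrile, a carboxylic acid or a longer chain such as ethoxy would give there stays open. All four compounds also keep their hydroxy group, and how the read-out would respond if a methoxy or an amine stood in its place is likewise left open.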